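The compounds below may be only part of what the source reports. "The series", "measured", "known", "first", "only" and "open" are said of these compounds alone.

Measured compounds in a functional assay on HeLa cells (Homo sapiens) for antiproliferative activity, with a stated time of 48 h; a higher number here means a weaker inhibitor, a lower number a stronger inhibitor:

Compound 1 `C=C(Br)C(=O)Nc1ccc(/C=C/C(=O)c2ccc(OCC)cc2)cc1`: compound 1 gives 750 nM.
Compound 2 `C=C(Br)C(=O)Nc1ccc(C(=O)/C=C/c2ccccc2)cc1`: compound 2 gives 960 nM.
Compound 3 `CCOc1ccc(C(=O)/C=C/c2ccc(N)cc2)cc1`: compound 3 gives 41000 nM.

Compound 1 and compound 2 are built on different cores; how the two cores differ is not broken down here, and their two values lie within the scatter of each other. Compound 3 is obtained from compound 1 by the change (hydrogen in place of (1-bromoethenyl)carbonyl on a nitrogen on an aromatic ring), and this gives a 55-fold higher number from compound 1 to compound 3 (1.74 log units; beyond the scatter).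

The unmeasured compound 4 `Nc1ccc(C(=O)/C=C/c2ccccc2)cc1` stands to compound 2 as compound 3 stands to compound 1: the change is hydrogen in place of (1-bromoethenyl)carbonyl on a nitrogen on an aromatic ring, made at a place described in the same words in both pairs, so it is the same change. Going by the values given here, only one measured instance of it exists, so the expectation for compound 4 rests on that single step alone. Compound 4 is expected to show a step of a 47-fold higher number from compound 2 to compound 4 (1.67 log units; beyond the scatter) in this assay, close in size to the step seen from compound 1 to compound 3, because that step was a 55-fold higher number from compound 1 to compound 3 (1.74 log units; beyond the scatter). Compound 4 is accordingly estimated at 45000 nM, with a likely range from 15000 nM to 150000 nM.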

Compound 4, half-maximal inhibitory concentration: 7700 nM
Compound 4: middle estimate off by 5.8-fold (0.77 log units), on the high side, and the stated range ends above it.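

On both cores, hydrogen in place of (1-bromoethenyl)carbonyl on the aromatic amine nitrogen weakens the antiproliferative effect in this assay, and on the core of compound 2 the change gives an 8.0-fold higher number from compound 2 to compound 4 (0.90 log units; beyond the scatter). The direction carries from one core to the other, but the size does not: the same change on two cores in this assay, a 55-fold higher number (1.74 log units; beyond the scatter) from compound 1 to compound 3 and an 8.0-fold higher number (0.90 log units; beyond the scatter) from compound 2 to compound 4, 6.8-fold (0.83 log units) apart, beyond the scatter of two such steps

Two cores are a small base, so this shows only that the size of the step depends on the core in this pair of examples, not which feature of the cores sets it or how the change would behave on a further core.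

The compounds shown leave open how an acetyl group or a (1-chloroethenyl)carbonyl group on the same nitrogen would compare, and so whether the bromine, the double bond or the carbonyl accounts for the step. They also leave open which of the differences between the two cores goes with the gap in step size.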